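Exchanging a Halogen for Methylsulfonyl in an EP3 Series

This account rests on a few compounds, and the source may have more. Where it says the series, first, only, none or still open, it means among the compounds named here.

The study measured three compounds in an assay on isolated protein for inhibition of prostaglandin E2 receptor EP3 subtype (Homo sapiens) (on this read-out higher numbers stand for weaker inhibition and lower numbers for stronger inhibition), and left a fourth untested. Compound 1 `O=C(O)c1cccc(C2=C(c3cc(Br)ccc3OCc3ccc(F)cc3)CCC2)c1` carries a bromo group and a fluorobenzyloxy group; compound 2 `O=C(O)c1cccc(C2=C(c3cc(Cl)ccc3OCc3ccccc3)CCC2)c1` carries chloro beside a plain benzyloxy group; compound 3 `CS(=O)(=O)c1ccc(OCc2ccc(F)cc2F)c(C2=C(c3cccc(C(=O)O)c3)CCC2)c1` pairs methylsulfonyl with a difluorobenzyloxy group. In this assay compound 2 reaches only a limit, < 3170 nM. Compound 1 likewise stops at a limit of < 3170 nM. Compound 3 too gives only a limit, < 3170 nM. Within the data shown here, compound 2 thus stands nowhere in particular among the three: the limit of < 3170 nM in this assay, at which 3 of the 3 values shown sit, so no ordering among them can be read, and no step between measured compounds is available.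

Compound 4 `CS(=O)(=O)c1ccc(OCc2ccccc2)c(C2=C(c3cccc(C(=O)O)c3)CCC2)c1` differs from compound 2 by a single change: methylsulfonyl in place of chloro on an aromatic carbon. Among the measured compounds shown here, with every measured value sitting at the limit, no direction for this step can be drawn from the data; the expected change in this assay is none beyond the scatter, and compound 4 is expected to fall again at or under the limit. Compound 3, which already carries the methylsulfonyl group, sits at a limit of < 3170 nM. Compound 4 is therefore estimated at 400 nM, within 30 nM to 3170 nM, the expected step being a step that the limit leaves unreadable from compound 2 to compound 4.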

Compound 4, half-maximal inhibitory concentration: < 3170 nM
Compound 4: only a limit was reported (the forecaster's own chance of this, stated with the estimate: 70%); the middle value does not contradict the limit.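

Compound 4 gives no readable step from compound 2 or from compound 3 in this assay, because the values offer no numbers to compare, only one shared limit: the limit of < 3170 nM in this assay, at which 4 of the 4 values shown sit.

The compounds shown leave open how methylsulfonyl and chloro, or phenyl and 2,4-difluorophenyl, actually compare in this assay.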